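Swapping an Aryl Cap for a Hydroxypiperidine Arm

The source may report more compounds than this note shows. Statements on the series, on what has been measured and on what is new or still open speak of the compounds shown alone.

Three compounds have been measured in a functional assay on MGC-803 cells (Homo sapiens) for cytotoxicity, read by MTT assay, with a stated time of 48 h; a higher number here means a weaker inhibitor, a lower number a stronger inhibitor:

Compound 1, `CC1=NN(C(=O)CCc2ccccc2)C(c2cc(Br)cc(Br)c2O)C1`, gives 17100 nM.
Compound 2, `CC(=O)Oc1ccccc1C1CC(C)=NN1C(=O)CN(C(C)C)C(C)C`, gives 20100 nM.
Compound 3, `Cc1ccc(C(=O)N2N=C(c3cc4ccccc4oc3=O)CC2c2ccccc2)cc1`, gives 31300 nM.

Compound 3 carries the highest of the three numbers in this assay, yet its gap to compound 2 and to compound 1 lies within the usual scatter, so no ordering among the three can be claimed. Compound 4, `O=C(CN1CCC(O)CC1)N1N=C(c2cc3ccccc3oc2=O)CC1c1ccccc1`, is not yet measured. It differs from compound 3 by (4-hydroxypiperidin-1-yl)methyl in place of 4-methylphenyl on a carbonyl carbon. Going by the values given here, no step between measured compounds is available to guide the size of this change. Compound 2, which also carries an aminomethyl carbonyl arm, sits close to compound 3, so the change is expected to stay within the scatter in this assay. Compound 4 is therefore estimated at 25000 nM, with a range from 10000 nM to 60000 nM, an expected step of a 1.3-fold lower number from compound 3 to compound 4 (0.10 log units; within the scatter).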

Compound 4, half-maximal inhibitory concentration: "not active" (no number reported)
Nothing numeric was reported for compound 4, and the estimate cannot be compared.
By their numbers in this assay, from the lowest: compounds 1, 2 and 3 (each within the scatter of the next).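

Going by these compounds alone, compound 4 was reported as not active, with no number, so no step from compound 3 to compound 4 can be read. On these data alone, how large the effect of this swap is remains open, and no evidence bears on it.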